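Tert-butyl to isopropyl on the bromo compound

The source may report more compounds than this note shows. Statements on the series, on what has been measured and on what is new or still open speak of the compounds shown alone.

In an ADME assay on HepG2 cells (Homo sapiens) for cytotoxicity, read by MTT assay, with a stated time of 72 h (on this read-out higher numbers stand for lower toxicity in this test and lower numbers for higher toxicity in this test), compound 1 `CC(C)(C)Nc1nc2cc(-c3ccc(Br)cc3)sc2c(=O)[nH]1` gives 1400 nM, the lower of the two measured numbers, and compound 2 `CC(C)(C)Nc1nc2cc(-c3ccc(F)cc3)sc2c(=O)[nH]1` gives 5100 nM. Compound 3 `CC(C)Nc1nc2cc(-c3ccc(Br)cc3)sc2c(=O)[nH]1` differs from compound 1 by hydrogen in place of methyl on a saturated chain carbon bound to a nitrogen on an aromatic ring and two saturated chain carbons, tert-butyl to isopropyl. Within the data shown here, the only measured step, a 3.6-fold higher number from compound 1 to compound 2 (0.56 log units; beyond the scatter), is fluoro in place of bromo on an aromatic carbon. It offers a modest scale but does not test the tert-butyl group. No step beyond the scatter is therefore expected in this assay, and no direction is favoured with confidence. The estimated step is a 1.2-fold higher number from compound 1 to compound 3 (0.08 log units; within the scatter). For compound 3 the estimated value is 1700 nM, with an expected range of 700 nM to 4500 nM.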

Compound 3, half-maximal cytotoxic concentration: 13400 nM
The estimate for compound 3 lay 7.9-fold (0.90 log units) below the measured number; the measured number lies above the stated range.
By their numbers in this assay, from the lowest: compound 1; then compound 2; then compound 3.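

Tert-butyl to isopropyl is not a silent change in this assay: the step is a 9.6-fold higher number from compound 1 to compound 3 (0.98 log units; beyond the scatter), towards lower toxicity in this test. This position on the saturated chain carbon therefore moves the read-out, as the aromatic halogen does, though only the bromo compound shows it. Nothing measured here accounts for this step.

Going by these compounds, whether the same change holds with fluoro on the aromatic carbon remains open. Also open, on these data alone, is whether an ethyl or cyclopropyl group in place of isopropyl would continue in the same direction.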